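A few compounds are considered here, and "the series" means these few. Any claim that something is new, unique, unknown or untested is made for them only; others in the source may bear on it.

Compound 1 `CCCCOC(=O)C(=O)C(CC)NC(=O)C(CC(C)C)NC(=O)OCc1ccccc1` is a peptide-like molecule carrying a benzyloxycarbonyl cap and a ketoester tail. In an assay on isolated protein (Oryctolagus cuniculus) for inhibition of Calpain-2 catalytic subunit (Homo sapiens), at pH 8.0 (a lower number here means a stronger inhibitor, a higher number a weaker inhibitor), compound 1 gives 400 nM, the lowest of the two numbers measured; compound 2 `CCOC(=O)C(=O)C(CC)NC(=O)C(CC(C)C)NS(=O)(=O)c1ccc2ccccc2c1`, which carries a naphthalenesulfonyl group instead, gives 2200 nM in this assay, a gap beyond the scatter. Compound 3 `CCCCCCCCNC(=O)C(=O)C(CC)NC(=O)C(CC(C)C)NC(=O)OCc1ccccc1` differs from compound 1 by a single change: octylamino in place of butoxy on a carbonyl carbon. Among the compounds with values here, no measured pair shows this kind of swap, so its effect is open. The ketoamide in compound 3 is expected to give a modestly lower number, a step of a 3.3-fold lower number from compound 1 to compound 3 (0.52 log units; beyond the scatter), estimated at 120 nM with a range from 25 nM to 600 nM.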

Compound 3, inhibition constant: 19 nM
For compound 3 the middle estimate is 6.3-fold (0.80 log units) above the measured one, and the stated range ends above it.
By their numbers in this assay, from the lowest: compound 3; then compound 1; then compound 2.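

The swap of octylamino in place of butoxy on a carbonyl carbon brings a 21-fold lower number from compound 1 to compound 3 (1.32 log units; beyond the scatter), so what sits at this position strongly affects the number. The change does two things at once: an ester becomes an amide that carries a hydrogen-bond donor, and the chain grows longer. This single step cannot separate those two parts, and no measurement at hand explains the gain. As far as these compounds go, it remains open whether butylamino, with its shorter chain, would give a similar number at this position. From the compounds shown here alone, the effect of a longer chain or of a benzylamino group there is also open.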